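Series notes: trimming the benzyl end of compound 3

A few compounds are considered here, and "the series" means these few. Any claim that something is new, unique, unknown or untested is made for them only; others in the source may bear on it.

Compound 3 `Nc1ccccc1COc1ccc(OCCOCCNC2CCCC2)cc1` gives 14000 nM in a functional assay on SK-OV-3 cells (Homo sapiens) for inhibition, read by CCK-8 assay, with a stated time of 70 h (on this read-out lower numbers stand for stronger inhibition and higher numbers for weaker inhibition), the lowest of the two numbers shown, with compound 2 `c1ccc(COc2ccc(OCCOCCNc3ccncc3)cc2)cc1` nearest at 20600 nM, a gap within the scatter. Compound 1 `c1ccc(COc2ccc(OCCOCCOC3CCCC3)cc2)cc1` sits at the assay limit of > 100000 nM. The step to compound 4 `CCOc1ccc(OCCOCCNC2CCCC2)cc1` is methyl in place of 2-aminophenyl on a saturated chain carbon bound to an oxygen on an aromatic ring. Among the compounds with values here, the only measured step, an at least 4.8-fold lower number from compound 1 to compound 2 (0.68 log units; beyond the scatter), changes the far end of the chain and does not bear on this change; no measured pair varies the group on the saturated chain carbon bound to the aromatic oxygen. The expectation for compound 4 is therefore a modest weakening, a 2.1-fold higher number from compound 3 to compound 4 (0.33 log units; beyond the scatter), with a real chance of no step beyond the scatter. Compound 4 is estimated at 30000 nM, between 10000 nM and 100000 nM.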

Compound 4, half-maximal inhibitory concentration: 90500 nM
For compound 4 the middle estimate is 3.0-fold (0.48 log units) below the measured one; the measured number falls inside the stated range.
By their numbers in this assay, from the lowest: compounds 3 and 2 (each within the scatter of the next); then compound 4. At a limit, above all of these: compound 1.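

In this assay, methyl in place of 2-aminophenyl on a saturated chain carbon bound to an oxygen on an aromatic ring gives a 6.5-fold higher number from compound 3 to compound 4 (0.81 log units; beyond the scatter), the only read so far on this position, and it shows that the group there counts in this series. Compound 4 now stands close to a limit of the read-out: the limit of > 100000 nM in this assay, at which 1 of the 4 values shown sits.

The change removes the aromatic ring and the amino group together, so their shares cannot be separated. As far as these compounds go, whether a longer chain or a cyclohexyl group in this place would recover the number stays open.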